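A few compounds are considered here, and "the series" means these few. Any claim that something is new, unique, unknown or untested is made for them only; others in the source may bear on it.

Among the measured compounds shown here, in an assay on CHO cells for displacement of a labelled ligand from 5-hydroxytryptamine receptor 1D (Homo sapiens) (on this read-out lower numbers stand for stronger inhibition and higher numbers for weaker inhibition), compound 2 `CC(C)=CCCN(C)C1CCN(CCCc2c[nH]c3ccc(-n4cnnc4)cc23)CC1` gives 2.6 nM, the lowest of the two numbers measured so far; compound 1 `c1ccc2c(c1)CCC2NC1CCN(CCCc2c[nH]c3ccc(-n4cnnc4)cc23)CC1` gives 8.9 nM, and the only step recorded, a 3.4-fold lower number from compound 1 to compound 2 (0.53 log units; beyond the scatter), separates them. Compound 3 `c1cncc(CNC2CCN(CCCc3c[nH]c4ccc(-n5cnnc5)cc34)CC2)c1` differs from compound 2 as follows: ((pyridin-3-yl)methyl)amino in place of methyl(4-methylpent-3-en-1-yl)amino on a saturated ring carbon. The entering group again carries a hydrogen-bond donor and a ring, as the group on compound 1 does, so that earlier step, read in reverse, is the one that bears here; a modest rise is therefore expected, a 2.3-fold higher number from compound 2 to compound 3 (0.36 log units; beyond the scatter). Compound 3 is expected at 6 nM, within 2 nM to 18 nM.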

Compound 3, half-maximal inhibitory concentration: 35 nM
Compound 3: middle estimate off by 5.8-fold (0.77 log units), on the low side; measured number above the stated range.
By their numbers in this assay, from the lowest: compound 2; then compound 1; then compound 3.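

In this assay, replacing the open chain at this saturated ring carbon costs far more than compound 1 suggested, with a 13-fold higher number from compound 2 to compound 3 (1.13 log units; beyond the scatter). A ring and a hydrogen-bond donor in the entering group therefore do not fix the number, for the amine nitrogen's substituent alone gives a 3.9-fold higher number from compound 1 to compound 3 (0.59 log units; beyond the scatter). Nothing measured here explains either step.

The compounds leave open whether a benzyl group on the amine nitrogen would sit with compound 1 or with compound 3. As far as these compounds go, it is also open whether the methyl or the 4-methylpent-3-en-1-yl chain sets compound 2 apart.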